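Cyano in Place of Formyl: Expected Cytotoxicity of Compound 4

The source may hold more compounds than are shown below. What is called first, only, known or untested is meant among the compounds shown, and "the series" means these compounds.

Measured compounds:
compound 1, `O=Cc1c(-c2ccccc2)sc2ccccc12`, 37%
compound 2, `O=Cc1c(-c2ccc(C(F)(F)F)cc2)sc2ccccc12`, 59%
compound 3, `N#Cc1ccccc1-c1sc2ccccc2c1C=O`, 33%

In a functional assay on MCF7R cells (Homo sapiens) for cytotoxicity, tested at 10 uM (on this read-out lower numbers stand for less inhibition and higher numbers for more inhibition at the one concentration tested (going by the name of the read-out)), compound 1 stands second highest of the three numbers: the nearest step is a number 4 percentage points lower from compound 1 to compound 3 (within the scatter), the furthest is a number 22 percentage points higher from compound 1 to compound 2 (beyond the scatter). Compound 4, `N#Cc1c(-c2ccccc2)sc2ccccc12`, differs from compound 1 by cyano in place of formyl on an aromatic carbon. Both measured steps exchange a hydrogen for trifluoromethyl or cyano on an aromatic carbon and leave the formyl untouched, so neither bears directly on this change; the data give no guide to its direction. Compound 4 is therefore expected to give about 36%, within 15% to 57%, which amounts to an estimated step of a number 1 percentage points lower from compound 1 to compound 4 (within the scatter), not beyond the scatter.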

Compound 4, a percentage reported as inhibition, at one concentration (the size of the read-out at that concentration, not a potency): 37%
Estimate against measurement, compound 4: 1 percentage points below; the measured number falls inside the stated range.
By their numbers in this assay, from the lowest: compounds 3, 1 and 4 (each within the scatter of the next); then compound 2.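

In this assay, exchanging the formyl on this aromatic carbon of the five-membered ring gives no change at the digits printed from compound 1 to compound 4 (within the scatter). This is the first change shown at this position, since the earlier steps all left the formyl in place, and compound 4 shows that the read-out at this one concentration does not depend on keeping a formyl there. Nothing measured here accounts for the two groups reading alike.

As far as these compounds go, whether a carboxylic acid or an amine at this position would read the same remains open. So does whether trifluoromethyl would raise the number with cyano in place of formyl.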